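Swapping piperidin-1-yl for 4-methylpiperazin-1-yl on compound 2

A few compounds are considered here, and "the series" means these few. Any claim that something is new, unique, unknown or untested is made for them only; others in the source may bear on it.

Compound 1 `CN(C)c1nc(Cl)nc2c1ncn2CCNc1ccnc2cc(Cl)ccc12`: > 11800 nM (a limit)
Compound 2 `Clc1ccc2c(NCCn3cnc4c(N5CCCCC5)nc(Cl)nc43)ccnc2c1`: > 10700 nM (a limit)

Both entries come from an ADME assay on Vero cells (Chlorocebus sabaeus) for cytotoxicity, read by neutral red uptake, with a stated time of 48 h (on this read-out lower numbers stand for stronger inhibition and higher numbers for weaker inhibition), and each is a limit of the assay, not a measured number. Compound 2 therefore stands only at its limit of > 10700 nM.

The next change leads to compound 3 `CN1CCN(c2nc(Cl)nc3c2ncn3CCNc2ccnc3cc(Cl)ccc23)CC1`, with 4-methylpiperazin-1-yl in place of piperidin-1-yl on an aromatic carbon.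

Going by the values given here, only one measured step bears on this, a step that the two limits leave unreadable from compound 1 to compound 2, which exchanged a group on that same carbon, and its size cannot be read. With no measured size to carry over, no step beyond the scatter is expected in this assay, and another limit seems likely. The expected step is a step that the limit leaves unreadable from compound 2 to compound 3. For compound 3 the estimate is 11000 nM, with an expected range from 5000 nM to 25000 nM.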

Compound 3, half-maximal inhibitory concentration: > 10400 nM
Compound 3: no number, only a limit (the forecaster's own chance of this, stated with the estimate: 80%); the middle value lies beyond the limit too.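

In this assay compound 3 gives > 10400 nM, a limit of the assay and not a number. Going by these compounds alone, compound 1, compound 2 and compound 3 all stand at limits, and no step between them can be read. Going by these compounds, whether dimethylamino, piperidin-1-yl and 4-methylpiperazin-1-yl differ at all on that aromatic carbon stays open.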